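Cyclopropyl for Methyl: Expected Stability of Compound 4

The source may report more compounds than this note shows. Statements on the series, on what has been measured and on what is new or still open speak of the compounds shown alone.

Compound 3 `Cc1c([C@H](C)Nc2nc(N)nc(N)c2C#N)c(-c2ccccc2)c(=O)n2cc(F)ccc12` gives 85% in an ADME assay on microsomes from liver (Mus musculus), read by LC-MS, using NADPH, with a stated time of 30 min, tested at 1 uM; a higher number here means that more of the compound is left, a lower number that less of the compound is left. Compound 1 `C[C@H](Nc1ncnc2[nH]cnc12)c1cc2ccc(F)cn2c(=O)c1-c1ccccc1` gives 94% in this assay, a value within the scatter of compound 3. Compound 2 `C[C@H](Nc1nc(N)nc(N)c1C#N)c1cc2ccc(F)cn2c(=O)c1-c1ccccc1` gives 42%. The large rise a number 43 percentage points higher from compound 2 to compound 3 (beyond the scatter) came from adding a methyl group; the other measured step, a number 52 percentage points lower from compound 1 to compound 2 (beyond the scatter), changed the group on the amine nitrogen and does not touch the position altered here. Compound 4 `C[C@H](Nc1nc(N)nc(N)c1C#N)c1c(-c2ccccc2)c(=O)n2cc(F)ccc2c1C1CC1` differs from compound 3 in one place: cyclopropyl in place of methyl on an aromatic carbon. Within the data shown here, no measured step exchanges one group for another at that aromatic carbon, so the evidence is thin. The expected step is therefore a number 5 percentage points lower from compound 3 to compound 4 (within the scatter), within the scatter. For compound 4 the estimate in this assay is 80%, with a range from 60% to 95%.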

Compound 4, percent of the compound remaining: 87%
Compound 4: the middle estimate sits 7 percentage points below what was measured; the range from low to high includes it.
By their numbers in this assay, from the lowest: compound 2; then compounds 3, 4 and 1 (each within the scatter of the next).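

At this aromatic carbon, the gain in this assay does not depend on methyl alone: cyclopropyl in place of hydrogen gives a number 45 percentage points higher from compound 2 to compound 4 (beyond the scatter), a large step. Exchanging cyclopropyl for methyl gives a number 2 percentage points higher from compound 3 to compound 4 (within the scatter), so the two groups cannot be told apart here, despite the added ring and heavy atoms. Nothing measured here explains why either group has this effect.

Still open, as far as these compounds go, is how an amine, a methoxy group or a longer chain such as propyl would behave at this carbon. From the compounds shown here alone, whether cyclopropyl matters with the amine-nitrogen group of compound 1 also remains open.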